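The source may hold more compounds than are shown below. What is called first, only, known or untested is meant among the compounds shown, and "the series" means these compounds.

Compound 1 `Cc1cc(C)cc(COc2ccc(-c3cc(CN4CCN(Cc5ccc(C(F)(F)F)cc5)CC4)no3)cc2)c1` gives 600 nM in a functional assay on Huh-7 cells (Homo sapiens) for antiproliferative activity, read by sulforhodamine B assay, with a stated time of 72 h; on this read-out lower numbers stand for stronger inhibition and higher numbers for weaker inhibition.
Compound 2 `N#Cc1ccccc1COc1ccc(-c2cc(CN3CCN(Cc4ccc(C(F)(F)F)cc4)CC3)no2)cc1` gives 5000 nM in this assay.
Compound 3 `Fc1ccccc1COc1ccc(-c2cc(CN3CCN(Cc4ccc(C(F)(F)F)cc4)CC3)no2)cc1` gives 1500 nM in this assay.

Among these three, compound 1 shows the lowest number in this assay; compound 3 is its nearest neighbour and compound 2 the furthest. Both measured steps away from compound 1 alter the same part of the molecule, the aryl group on a saturated chain carbon bound to an oxygen on an aromatic ring: an 8.3-fold higher number from compound 1 to compound 2 (0.92 log units; beyond the scatter) and a 2.5-fold higher number from compound 1 to compound 3 (0.40 log units; beyond the scatter). Between the two replacements, a 3.3-fold lower number from compound 2 to compound 3 (0.52 log units; beyond the scatter).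

Compound 4 `COc1cccc(COc2ccc(-c3cc(CN4CCN(Cc5ccc(C(F)(F)F)cc5)CC4)no3)cc2)c1` differs from compound 1 in the same place: 3-methoxyphenyl in place of 3,5-dimethylphenyl on a saturated chain carbon bound to an oxygen on an aromatic ring. The two measured changes at this position both raised the number, one by a modest amount and one more sharply. A single substituent on the entering ring, rather than two, sits closer to those cases than to the starting point, so a modest rise is expected, a 2.0-fold higher number from compound 1 to compound 4 (0.30 log units; within the scatter). Compound 4 is therefore estimated at 1200 nM in this assay, with a range from 500 nM to 3500 nM.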

Compound 4, half-maximal inhibitory concentration: 800 nM
The estimate for compound 4 lay 1.5-fold (0.18 log units) above the measured number; the range from low to high includes it.
By their numbers in this assay, from the lowest: compounds 1, 4 and 3 (each within the scatter of the next, the first and the last beyond it); then compound 2.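

Unlike compound 2 and compound 3, compound 4 cannot be told apart from compound 1 in this assay, with a 1.3-fold higher number from compound 1 to compound 4 (0.12 log units; within the scatter) and so the rise seen with the earlier replacements of 3,5-dimethylphenyl does not extend to every aryl group at this position. Compound 4 also stays within the scatter of compound 3, with a 1.9-fold lower number from compound 3 to compound 4 (0.27 log units; within the scatter) while a 6.3-fold lower number from compound 2 to compound 4 (0.80 log units; beyond the scatter) is beyond it, which leaves compound 2 as the only one of the three replacements clearly separated from compound 4. No measurement shown here bears on the reason for these differences.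

The compounds shown leave open how an unsubstituted phenyl, or a ring carrying a carboxylic acid or an amine, would behave at this position. They also leave open whether this result extends to a 3-ethoxyphenyl group.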